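A few compounds are considered here, and "the series" means these few. Any claim that something is new, unique, unknown or untested is made for them only; others in the source may bear on it.

Measured so far:
compound 1, `O=C(O)CCC/C=C\CC1C2CCC(C2)C1NS(=O)(=O)c1ccccc1`, 2.9 nM
compound 2, `O=C(O)CCC/C=C\C[C@H]1CCC[C@H]1NS(=O)(=O)c1ccccc1`, 36 nM

In an assay for binding affinity to thromboxane A2 receptor (Homo sapiens), read by radioligand binding (on this read-out lower numbers stand for tighter binding and higher numbers for weaker binding), compound 2 gives 36 nM, the higher of the two numbers measured; compound 1 gives 2.9 nM, and the gap between them is beyond the usual scatter. Compound 3, `O=C(O)CCC/C=C\C[C@H]1CCC[C@@H]1NS(=O)(=O)c1ccccc1`, has not been measured. Compared with compound 2, (the two compounds have the same atoms and bonds and differ only in configuration as drawn: 1 of 3 stereo elements differ; a stereocentre at a saturated ring carbon is drawn R in compound 2 and S in compound 3); the two compounds have the same atoms and bonds and differ only in configuration as drawn. For the measured compounds named here, no measured pair shows such a change, so its effect is uncertain, but a step of the size a 2.8-fold higher number from compound 2 to compound 3 (0.44 log units; beyond the scatter) toward weaker binding is expected. For compound 3 the estimate is 100 nM, with a range from 20 nM to 600 nM.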

Compound 3, dissociation constant: 7.5 nM
Estimate against measurement, compound 3: 13-fold (1.12 log units) above; the measured number lies below the stated range.
By their numbers in this assay, from the lowest: compound 1; then compound 3; then compound 2.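

In this assay, changing the configuration at one saturated ring carbon is enough to shift binding beyond the usual scatter: a 4.8-fold lower number from compound 2 to compound 3 (0.68 log units; beyond the scatter). For the compounds shown here, this is the first pair here in which a stereocentre is the only change, and the form drawn S binds more tightly while the other stereo elements stay as drawn. The step can be assigned to that stereocentre because nothing else separates the pair: the fact that compounds 2 and 3 differ only in the configuration as drawn. Still open, from the compounds shown here alone, is whether the other ring stereocentre matters as much, and how a tetrazole in place of the carboxylic acid would bind.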